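Chloro to Methyl: A Step into Untested Ground

A few compounds are considered here, and "the series" means these few. Any claim that something is new, unique, unknown or untested is made for them only; others in the source may bear on it.

Compound 3 `O=C(Nc1nnc(-c2ccc(Cl)cc2)s1)c1ccccc1Cl` gives only a limit of the assay in a functional assay on the whole organism (integument) for inhibition, with Chilo suppressalis as the target, read by scintillation counting, with a stated time of 72 h (a lower number here means a stronger inhibitor, a higher number a weaker inhibitor), namely > 5010 nM. Compound 1 `O=C(Nc1nnc(-c2ccc(Cl)cc2)s1)c1ccccc1` likewise reaches only a limit, giving > 5010 nM. Compound 2 `O=C(Nc1nnc(-c2ccc(Cl)cc2)s1)c1ccccc1F` gives a number, 724 nM. Among the measured steps there is an at least 6.9-fold lower number from compound 1 to compound 2 (0.84 log units; beyond the scatter), there is a step that the two limits leave unreadable from compound 1 to compound 3, and there is an at least 6.9-fold higher number from compound 2 to compound 3 (0.84 log units; beyond the scatter). Compound 4 `Cc1ccccc1C(=O)Nc1nnc(-c2ccc(Cl)cc2)s1` differs from compound 3 by methyl in place of chloro on an aromatic carbon, that is, 2-chlorophenyl to 2-methylphenyl. Within the data shown here, no measured step involves methyl, so the only guidance is that chloro and hydrogen both sat at the limit of > 5010 nM in this assay, at which 2 of the 3 values shown sit, while fluoro alone gave a readable number. Compound 4 is therefore expected to stay weak, an at least 1.6-fold lower number from compound 3 to compound 4 (0.22 log units; that floor lies within the scatter), with an estimated 3000 nM between 600 nM and 15000 nM.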

Compound 4, half-maximal inhibitory concentration: 158 nM
Estimate against measurement, compound 4: 19-fold (1.28 log units) above; the whole stated range lies above it.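

Methyl in place of chloro gives an at least 31-fold lower number from compound 3 to compound 4 (1.50 log units; beyond the scatter), and methyl in place of hydrogen gives an at least 31-fold lower number from compound 1 to compound 4 (1.50 log units; beyond the scatter), so fluoro is not the only group at this position that brings a readable number. Methyl also goes further than fluoro, with a 4.6-fold lower number from compound 2 to compound 4 (0.66 log units; beyond the scatter), while chloro and methyl, each a single heavy atom, end far apart. The two large steps are floors, since each starts from a limit: the limit of > 5010 nM in this assay, at which 2 of the 4 values shown sit.

From the compounds shown here alone, whether an ethyl group, a longer chain, a methoxy group or an amine at this position would match methyl remains open.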